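The source may hold more compounds than are shown below. What is called first, only, known or untested is meant among the compounds shown, and "the series" means these compounds.

Two compounds of the series have numbers in a functional assay on PC-3 cells (Homo sapiens) for cytotoxicity, read by MTT assay, with a stated time of 72 h; on this read-out higher numbers stand for weaker inhibition and lower numbers for stronger inhibition. Compound 1 `CCCC(Nc1cncc(-c2ccc(O)c(OC)c2)n1)c1cccc(F)c1` gives 600 nM. Compound 2 `CCC[C@H](Nc1cc(-c2ccc(NC(=O)NCC)c(OC)c2)ncn1)c1cccnc1` gives 100 nM, the lowest of the two numbers, and its gap to compound 1 lies beyond the scatter. Compound 3 `CCC[C@H](Nc1cc(-c2ccc(NC(=O)NCC)c(OC)c2)nc(C)n1)c1cccnc1` carries methyl in place of hydrogen on an aromatic carbon. Among the compounds with values here, no measured pair tracks a change of this kind, so the size of the step rests on the change alone, a single added carbon on the shared core. For the step of a 1.3-fold higher number from compound 2 to compound 3 (0.11 log units; within the scatter) the expectation is a shift within the scatter, in no firm direction. For compound 3 the estimate is 130 nM, with a range from 50 nM to 350 nM.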

Compound 3, half-maximal inhibitory concentration: 80 nM
Compound 3: middle estimate off by 1.6-fold (0.21 log units), on the high side; low and high end bracket the measured number.
By their numbers in this assay, from the lowest: compounds 3 and 2 (each within the scatter of the next); then compound 1.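

In this assay, methyl in place of hydrogen on the aromatic carbon between two ring nitrogen atoms gives a 1.3-fold lower number from compound 2 to compound 3 (0.10 log units; within the scatter) and so leaves the number unmoved beyond the scatter. Within the data shown here, this is the first reading at this position, and it shows that the carbon carries a methyl with the potency of compound 2 kept. Nothing at hand bears on a cause for this result. From the compounds shown here alone, whether an ethyl, an amine or a methoxy group on this carbon would also stay within the scatter of compound 2 remains open.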